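Butylamino series: hydroxy for terminal methyl at the chain end

The source may report more compounds than this note shows. Statements on the series, on what has been measured and on what is new or still open speak of the compounds shown alone.

Compound 3 `CCCCNc1ncc(-c2cccc(Cl)c2)c(-c2ccccc2)n1` gives 56% in an assay on CHO cells for displacement of a labelled ligand from adenosine receptor A1 (Homo sapiens), read by scintillation counting, with a stated time of 1 h, tested at 1 uM; on this read-out higher numbers stand for more inhibition at the one concentration tested (going by the name of the read-out) and lower numbers for less inhibition. Compound 2 `O=C(Nc1ncc(-c2cccc(Cl)c2)c(-c2ccccc2)n1)C1CCC1` gives 52%, and a number 4 percentage points higher from compound 2 to compound 3 (within the scatter). Compound 1 `CCCC(=O)Nc1ncc(-c2cccc(Cl)c2)c(-c2ccccc2)n1` is reported only as a limit, > 80%, which is the limit of > 80% in this assay, at which 1 of the 3 values shown sits. The measured steps are a number at least 28 percentage points lower from compound 1 to compound 2 (beyond the scatter) and a number at least 24 percentage points lower from compound 1 to compound 3 (beyond the scatter); both concern the group on the ring nitrogen, not the chain end. Compound 4 `OCCCNc1ncc(-c2cccc(Cl)c2)c(-c2ccccc2)n1` differs from compound 3 by hydroxy in place of methyl on a saturated chain carbon, three bonds along the chain from a nitrogen on an aromatic ring. For the measured compounds named here, no measured step touches this position, so the size of the step is not anchored by the data. The expectation is a number 8 percentage points lower from compound 3 to compound 4 (within the scatter), within the scatter. Compound 4 is therefore estimated at 48%, with a range from 22% to 72%.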

Compound 4, a percentage reported as inhibition, at one concentration (the size of the read-out at that concentration, not a potency): > 80%
Compound 4: only a limit was reported; the forecaster's own chance of this, stated with the estimate: 5%; middle value at least 32 percentage points away from the limit.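

Hydroxy in place of methyl at the chain end gives the first measured step at this position, and in this assay it is a number at least 24 percentage points higher from compound 3 to compound 4 (beyond the scatter). With 3-hydroxypropyl in place of cyclobutylcarbonyl on the same nitrogen, the reading is a number at least 28 percentage points higher from compound 2 to compound 4 (beyond the scatter). Compound 4 and compound 1 are both reported as limits, so the step between them cannot be read: the limit of > 80% in this assay, at which 2 of the 4 values shown sit.

On these data alone, the true size of the reading for compound 4 stays open. Also open, as far as these compounds go, is whether hydroxy is specifically required, which a methoxy, an amine or a carboxylic acid at the chain end, or a longer chain ending in hydroxy, would test.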